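The compounds below may be only part of what the source reports. "The series", "measured", "known", "first", "only" and "open" are said of these compounds alone.

Compound 1 `O=C(Nc1cc(F)c(F)c(F)c1)c1cc(=O)[nH]c2cc(Br)ccc12`: > 20000 nM (a limit)
Compound 2 `COc1ccc2c(C(=O)Nc3cc(F)cc(F)c3)cc(=O)[nH]c2n1`: > 20000 nM (a limit)
Compound 3 `O=C(Nc1cccc(F)c1)c1cc(=O)[nH]c2cc(-c3ccc(F)cc3)ccc12`: 3300 nM

For the measured compounds named here, in a functional assay on KYSE-70 cells for antiproliferative activity against KYSE-70 cell line (Homo sapiens), read by MTT assay, with a stated time of 72 h (on this read-out lower numbers stand for stronger inhibition and higher numbers for weaker inhibition), compound 3 gives 3300 nM, the only true number among the three results. The other two results are not numbers but assay limits: the limit of > 20000 nM in this assay, at which 2 of the 3 values shown sit.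

Compound 4 `O=C(Nc1cccc(F)c1)c1cc(=O)[nH]c2cc(-c3ccncc3)ccc12` has pyridin-4-yl in place of 4-fluorophenyl on an aromatic carbon. Going by the values given here, no measured pair of compounds differs in just one place, so the size of this step is a judgement. A modest weakening is expected, though a change within the scatter would be no surprise. The expected step of a 1.8-fold higher number from compound 3 to compound 4 (0.26 log units; within the scatter) is therefore small. For compound 4 the estimated value is 6000 nM, with an expected range of 1800 nM to 20000 nM.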

Compound 4, half-maximal inhibitory concentration: > 20000 nM
Compound 4: no number, only a limit; the forecaster's own chance of this, stated with the estimate: 25%; at least 3.3-fold (0.52 log units) between middle value and limit.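

In this assay, pyridin-4-yl in place of 4-fluorophenyl on this aromatic carbon gives an at least 6.0-fold higher number from compound 3 to compound 4 (0.78 log units; beyond the scatter), so the result depends on the group at this place. The earlier compounds shown here differed in several places at once and could not show this. For compound 4 the result is a limit and not a number, so the full size of the step stays unknown: the limit of > 20000 nM in this assay, at which 3 of the 4 values shown sit.

On these data alone, it remains open whether the loss of the fluorine or the arrival of the ring nitrogen matters more. A plain phenyl ring or an amine at this place could help separate the two.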